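Chain extension on two related diaryl cores

The compounds below may be only part of what the source reports. "The series", "measured", "known", "first", "only" and "open" are said of these compounds alone.

Compound 1 `CCCCCCn1nc(-c2ccccc2)c(-c2ccccc2)cc1=O`: 57000 nM
Compound 2 `CCCCCCCn1nc(-c2ccccc2)c(-c2ccccc2)cc1=O`: 86000 nM
Compound 3 `CCCCCCOc1cc(-c2ccccc2)c(-c2ccccc2)nn1`: 72000 nM

In an assay on microsomes from liver for inhibition of sterol O-acyltransferase 1 (Rattus norvegicus) (on this read-out higher numbers stand for weaker inhibition and lower numbers for stronger inhibition), compound 1 gives 57000 nM and compound 2 gives 86000 nM. The change between them, (methyl in place of hydrogen on a saturated chain carbon, six bonds along the chain from an aromatic nitrogen), made a step of a 1.5-fold higher number from compound 1 to compound 2 (0.18 log units; within the scatter). Compound 3 has the same atoms as compound 1 joined differently; the difference between the two cores is not broken down here. In this assay compound 3 gives 72000 nM.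

Compound 4 `CCCCCCCOc1cc(-c2ccccc2)c(-c2ccccc2)nn1` carries the same kind of change on the core of compound 3, namely (methyl in place of hydrogen on a saturated chain carbon, six bonds along the chain from an oxygen on an aromatic ring); the place differs in that the chain is counted from an oxygen on an aromatic ring rather than from an aromatic nitrogen. Because a 1.5-fold higher number from compound 1 to compound 2 (0.18 log units; within the scatter) stayed within the scatter, compound 4 is expected to differ from compound 3 by a 1.3-fold higher number from compound 3 to compound 4 (0.10 log units; within the scatter). Compound 4 is thus expected near 90000 nM, between 40000 nM and 200000 nM.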

Compound 4, half-maximal inhibitory concentration: 58000 nM
Compound 4: middle estimate off by 1.6-fold (0.19 log units), on the high side; the range from low to high includes it.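

On the core of compound 3, the added methyl gave a 1.2-fold lower number from compound 3 to compound 4 (0.09 log units; within the scatter). Set beside the earlier step, this shows no difference between the two cores: the same change on two cores in this assay, a 1.5-fold higher number (0.18 log units; within the scatter) from compound 1 to compound 2 and a 1.2-fold lower number (0.09 log units; within the scatter) from compound 3 to compound 4, 1.9-fold (0.27 log units) apart, within the scatter of two such steps

Neither step stands clear of the scatter, so the two cores agree only in that this change has no readable effect on either, and the result does not show that a real effect carries from one core to the other. What the compounds shown leave open is whether a longer chain, or a chain carrying an amine or a carboxylic acid, would move the number beyond the scatter on either core, and whether the two cores would then respond alike.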